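Inverting one ring stereocentre in a thioether acid

The compounds below may be only part of what the source reports. "The series", "measured", "known", "first", "only" and "open" are said of these compounds alone.

Three compounds were measured in an assay on isolated protein for inhibition of betaine--homocysteine S-methyltransferase 1 (Homo sapiens), with a stated time of 30 min, tested at 20 uM; on this read-out lower numbers stand for less inhibition and higher numbers for more inhibition at the one concentration tested (going by the name of the read-out). Compound 1 `NC(CCSCCCCC(=O)O)c1nnn[nH]1` gives 0%, compound 2 `NC(CCSCCCCC(=O)O)c1nc(=O)o[nH]1` gives 15%, and compound 3 `O=C(O)CCCCS[C@@H]1CN[C@H](C(=O)O)C1` gives 24%. Among the measured compounds shown here, the one single-point step, a number 15 percentage points higher from compound 1 to compound 2 (beyond the scatter), concerns a ring swap. Compound 3 sits beyond compound 1 by a margin beyond the scatter, while its gap to compound 2 lies within the scatter. Compound 4 `O=C(O)CCCCS[C@H]1CN[C@H](C(=O)O)C1` differs from compound 3 as follows: the two compounds have the same atoms and bonds and differ only in configuration as drawn: 1 of 2 stereo elements differ; a stereocentre at a saturated ring carbon is drawn S in compound 3 and R in compound 4. No measured step in this assay involves a change of configuration, so nothing shown bears directly on this step, and no shift beyond the scatter is assumed. Compound 4 is therefore expected to give 20% (range 0% to 45%), an estimated step of a number 4 percentage points lower from compound 3 to compound 4 (within the scatter), though a real shift in either direction cannot be ruled out.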

Compound 4, a percentage reported as inhibition, at one concentration (the size of the read-out at that concentration, not a potency): 0%
Estimate against measurement, compound 4: 20 percentage points above; the range from low to high includes it.
By their numbers in this assay, from the lowest: compounds 1 and 4 (each within the scatter of the next); then compounds 2 and 3 (each within the scatter of the next).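

In this assay, among the compounds shown here, configuration at a saturated ring carbon matters, which no earlier step could show: a number 24 percentage points lower from compound 3 to compound 4 (beyond the scatter). Drawn S at this stereocentre, the thioether acid retains a measurable read-out, whereas drawn R it does not. The shift can be assigned to this one stereocentre, because nothing else separates the pair: the fact that compounds 3 and 4 differ only in the configuration as drawn. The compounds shown leave open whether the other stereocentre is equally sensitive, and whether the preference for S persists with a longer chain or with an amide in place of the chain's carboxylic acid.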